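From 2-(allyloxy)phenyl to 3-(allyloxy)phenyl

The compounds below may be only part of what the source reports. "The series", "measured", "known", "first", "only" and "open" are said of these compounds alone.

Measured so far in a functional assay on Jurkat cells (Homo sapiens) for inhibition, read by MTT assay, with a stated time of 72 h; a higher number here means a weaker inhibitor of growth, a lower number a stronger inhibitor of growth:
Compound 1 `O=C1CC(N2C(=O)CSC2=S)C(=O)N1c1ccc(Cl)cc1`: 88400 nM
Compound 2 `O=C1CC(N2C(=O)/C(=C/C(Cl)=C/c3ccc([N+](=O)[O-])cc3)SC2=S)C(=O)N1c1ccc(Cl)cc1`: 3400 nM
Compound 3 `C=CCOc1ccccc1/C=C1\SC(=S)N(C2CC(=O)N(c3ccc(Cl)cc3)C2=O)C1=O`: 53300 nM

Compound 3 stands within the scatter of compound 1, and its number is far higher than that of compound 2, a gap well beyond the scatter. Compound 4 `C=CCOc1cccc(/C=C2\SC(=S)N(C3CC(=O)N(c4ccc(Cl)cc4)C3=O)C2=O)c1` carries 3-(allyloxy)phenyl in place of 2-(allyloxy)phenyl on a double-bonded chain carbon bound to a double-bonded ring carbon. Going by the values given here, no measured pair shows what such a change does, so the expectation in this assay is no step beyond the scatter. The estimated change is a 1.3-fold lower number from compound 3 to compound 4 (0.12 log units; within the scatter). For compound 4 the expected value is 40000 nM, with an estimated range from 15000 nM to 100000 nM.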

Compound 4, concentration for 50% growth inhibition: 74000 nM
Beside the measured number, compound 4's estimate is 1.9-fold (0.27 log units) below it; measured number inside the range.
By their numbers in this assay, from the lowest: compound 2; then compounds 3, 4 and 1 (each within the scatter of the next).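

In this assay, going by these compounds alone, this is the first step read at this place: 3-(allyloxy)phenyl in place of 2-(allyloxy)phenyl on a double-bonded chain carbon bound to a double-bonded ring carbon gives a 1.4-fold higher number from compound 3 to compound 4 (0.14 log units; within the scatter). The two placements of the allyloxy group therefore cannot be told apart in this assay, at least for this pair. Nothing at hand explains the result.

Going by these compounds, whether a carboxylic acid or an amine in place of the allyloxy group would give a step beyond the scatter remains open.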